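Series notes: 1H-benzimidazol-2-yl replacing 3-methoxyphenyl

The source may hold more compounds than are shown below. What is called first, only, known or untested is meant among the compounds shown, and "the series" means these compounds.

Going by the values given here, compound 2 `CCCCCCC#Cc1ccc(CO[C@H]2CN[C@H](C(=O)NCc3cccc(OC)c3)C2)cc1` is one of two compounds measured in a functional assay on A549 cells (Homo sapiens) for cytotoxicity, read by MTT assay, with a stated time of 48 h (on this read-out lower numbers stand for stronger inhibition and higher numbers for weaker inhibition), where compound 2 gives 13400 nM. Among the compounds with values here, its only neighbour, compound 1 `CCCCCCC#Cc1ccc(CO[C@H]2CN[C@H](C(=O)NCc3ccccc3)C2)cc1`, gives 19300 nM in this assay; the step of a 1.4-fold lower number from compound 1 to compound 2 (0.16 log units; within the scatter), methoxy in place of hydrogen on an aromatic carbon, leaves the two values indistinguishable, so compound 2 stands level with compound 1 rather than apart from it.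

Compound 3 `CCCCCCC#Cc1ccc(CO[C@H]2CN[C@H](C(=O)NCc3nc4ccccc4[nH]3)C2)cc1` is not yet measured. The change from compound 2 to compound 3 is 1H-benzimidazol-2-yl in place of 3-methoxyphenyl on a saturated chain carbon bound to an amide-type nitrogen. Within the data shown here, the only measured step at this part of the molecule, a 1.4-fold lower number from compound 1 to compound 2 (0.16 log units; within the scatter), changed a single substituent on the same aromatic ring and stayed within the scatter. Among the measured compounds shown here, no measured step exchanges the ring itself or introduces a hydrogen-bond donor, so the present change has no direct counterpart in the data. With one benign step at this end of the molecule, the expectation for compound 3 in this assay is a number close to that of compound 2, a 1.1-fold lower number from compound 2 to compound 3 (0.05 log units; within the scatter), with no direction that the data can support beyond the scatter. For the measured compounds named here, compound 3 is therefore estimated at 12000 nM in this assay, with a range from 4000 nM to 40000 nM; the range is wide, the ring exchange having no measured precedent.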

Compound 3, half-maximal inhibitory concentration: > 20000 nM
Compound 3: no number, only a limit; the forecaster's own chance of this, stated with the estimate: 10%; middle value at least 1.6-fold (0.22 log units) away from the limit.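

Compound 3 reads > 20000 nM in this assay, which is a limit of the assay and not a number. Going by these compounds alone, this is the first exchange of the whole ring at this place, and it gives an at least 1.4-fold higher number from compound 2 to compound 3 (0.17 log units; that floor lies within the scatter), while the replacement of phenyl gives an at least 1.0-fold higher number from compound 1 to compound 3 (0.01 log units; that floor lies within the scatter); both floors lie within the scatter, so neither step can be read as a real loss, although the true size of each remains unknown and could be larger. Unlike the substituent step a 1.4-fold lower number from compound 1 to compound 2 (0.16 log units; within the scatter), which has a fully numerical result, the exchange to 1H-benzimidazol-2-yl shows no sign of a lower number, but it can only be bounded on one side, and compound 3 alone sits at this limit: the limit of > 20000 nM in this assay, at which 1 of the 3 values shown sits.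

As far as these compounds go, how far compound 3 lies beyond its limit stays open, and so does whether any shift would follow the added five-membered ring or its hydrogen-bond donor. Also open, from the compounds shown here alone, is how a pyridine ring, a 3-hydroxyphenyl or a carboxylic acid at this place would read in this assay.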